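Swapping the sulfonamide substituent in a kinase inhibitor series

The source may hold more compounds than are shown below. What is called first, only, known or untested is meant among the compounds shown, and "the series" means these compounds.

Measured compounds:
compound 1, `CC[C@@H]1C(=O)N(C)c2cnc(Nc3ccc(S(=O)(=O)Nc4ccccc4)cc3)nc2N1C1CCCC1`, 54.4 nM
compound 2, `CCCCNS(=O)(=O)c1ccc(Nc2ncc3c(n2)N(c2ccn(C)n2)C(CC)C(=O)N3C)cc1`, 191 nM
compound 3, `CCCCNC(=O)c1ccc2c(ccn2-c2ncc3c(n2)N(c2ccn(C)n2)C(CC)C(=O)N3C)c1`, 159 nM

Of the compounds shown here, three have been tested in an assay for inhibition of serine/threonine-protein kinase PLK2 (Homo sapiens), read by FRET and Z'-LYTE, with a stated time of 1 h; a higher number here means a weaker inhibitor, a lower number a stronger inhibitor. Compound 1 gives 54.4 nM, the lowest of the three numbers. Compound 3 gives 159 nM and compound 2 gives 191 nM, both of them beyond the scatter away from compound 1. None of these pairs differs in one place only, so no single step can be read from them; each of compound 2 and compound 3 changes the core as well as the group on the sulfonamide or amide, and their values show only what those whole molecules do.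

Compound 4, `CC[C@@H]1C(=O)N(C)c2cnc(Nc3ccc(S(=O)(=O)NCC(C)C)cc3)nc2N1C1CCCC1`, is not yet measured. It is compound 1 with one change: isobutyl in place of phenyl on a sulfonamide nitrogen. Within the data shown here, no measured pair shows this change by itself, so its effect in this assay is open. Since compound 2, with an alkyl chain in that position on a different core, still reaches 191 nM, a wholesale loss is not expected; a small step is the likelier outcome. The estimated step of a 1.7-fold higher number from compound 1 to compound 4 (0.22 log units; within the scatter) is a modest weakening, within or near the scatter. Compound 4 is therefore expected to give about 90 nM, in the range from 35 nM to 250 nM.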

Compound 4, half-maximal inhibitory concentration: 21.8 nM
Compound 4: middle estimate off by 4.1-fold (0.62 log units), on the high side, outside the stated range (below it).
By their numbers in this assay, from the lowest: compound 4; then compound 1; then compounds 3 and 2 (each within the scatter of the next).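

In this assay, among these compounds, the change at this sulfonamide nitrogen can now be read by itself for the first time, and it is a 2.5-fold lower number from compound 1 to compound 4 (0.40 log units; beyond the scatter). On the core of compound 1, then, an aromatic ring on this nitrogen is not required for inhibition, and isobutyl, with no ring and fewer heavy atoms than phenyl, goes with the lower number. The steps to compound 2 and compound 3 cannot be read, so this result rests on a single pair on a single core, and no measurement given here accounts for the difference between phenyl and isobutyl.

The compounds shown leave open whether a longer chain, a benzyl group or a cyclopropylmethyl group on this sulfonamide nitrogen would lower the number further, and whether an amine or a carboxylic acid at the end of the chain would be compatible with inhibition. They also leave open whether isobutyl in place of the butyl chain of compound 2, on that compound's own core, would change its number at all.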